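The compounds below may be only part of what the source reports. "The series", "measured", "known", "first", "only" and "open" are said of these compounds alone.

Two compounds in this set already have numbers in an assay on cells for inhibition of cytochrome P450 11B2, mitochondrial (Homo sapiens); a lower number here means a stronger inhibitor, a higher number a weaker inhibitor. Compound 1, `C[C@@H](c1ccc(Cl)cc1)N1Cc2cncn2C(CC2(C)COC2)S1(=O)=O`, gives 7.8 nM there. Compound 2, `CC(C)CC1n2cncc2CN(Cc2ccc(F)cc2)S1(=O)=O`, gives 2.5 nM in this assay. Of the two, compound 1 carries the higher number; its nearest neighbour is compound 2, whose number is lower by a margin beyond the scatter of repeated measurements, so compound 2 is the stronger inhibitor of the pair. For the measured compounds named here, compound 1 and compound 2 differ in more than one place, so no single step can be drawn between them; only their two values can be compared.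

Compound 3, `CC(C)CC1n2cncc2CN([C@@H](C)c2ccc(Cl)cc2)S1(=O)=O`, has not yet been measured in this assay. It comes from compound 1 by one change: isopropyl in place of 3-methyloxetan-3-yl on a saturated chain carbon bound to a saturated ring carbon. Going by the values given here, the isobutyl chain that enters is the one already present in compound 2, while the rest of compound 3 matches compound 1. Because compound 2 gives 2.5 nM with that isobutyl chain in place, the expected step is a 2.6-fold lower number from compound 1 to compound 3 (0.41 log units; beyond the scatter), toward a lower number. Compound 3 is therefore expected to give about 3 nM, within a range from 1.2 nM to 8 nM.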

Compound 3, half-maximal inhibitory concentration: 9.4 nM
For compound 3 the middle estimate is 3.1-fold (0.50 log units) below the measured one, outside the stated range (above it).
By their numbers in this assay, from the lowest: compound 2; then compounds 1 and 3 (each within the scatter of the next).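

In this assay, replacing 3-methyloxetan-3-yl with isopropyl on a saturated chain carbon bound to a saturated ring carbon gives a 1.2-fold higher number from compound 1 to compound 3 (0.08 log units; within the scatter), so this pair shows no measurable difference between the two groups. At this place, in this setting, the assay does not separate a chain bearing a four-membered ring with an oxygen from the smaller isobutyl chain, something the first two compounds could not show, as they differ in more than one place. Compound 3 also carries the isobutyl chain of compound 2, which gives 2.5 nM, so that chain alone does not bring the number down to that value, and nothing on hand explains why the swap leaves the number unmoved.

One pair cannot show how much freedom this place allows, and a longer chain, an amine or a carboxylic acid there could read quite differently. For the compounds shown here, it also stays open whether the same swap would be as silent with the group on the ring nitrogen of compound 2 in place of the one shared by compound 1 and compound 3.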